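The source may report more compounds than this note shows. Statements on the series, on what has been measured and on what is new or still open speak of the compounds shown alone.

Measured compounds:
compound 1 `N#Cc1c(N)nc(SCC(N)=O)c(C#N)c1-c1ccc(OCC2CC2)cc1`: 8%
compound 2 `N#Cc1c(N)nc(SCc2nnn[nH]2)c(C#N)c1-c1ccc(OCC2CC2)cc1`: 1%
compound 3 `COC(=O)c1cccc(CSc2nc(N)c(C#N)c(-c3ccc(OCC4CC4)cc3)c2C#N)c1`: 4%

In an assay on CHO cells for displacement of a labelled ligand from adenosine receptor A3 (Homo sapiens), read by scintillation counting, with a stated time of 120 min, tested at 1 uM (a higher number here means more inhibition at the concentration tested (going by the name of the read-out), a lower number less inhibition), compound 1 gives 8%, compound 2 gives 1% and compound 3 gives 4%. All three numbers lie within the scatter of one another, so no order among them can be read; compound 3 has compound 2 as its nearest neighbour and compound 1 as its furthest, and both gaps are small.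

The three measured compounds differ only at the saturated chain carbon bound to a sulfur. The steps there are a number 7 percentage points lower from compound 1 to compound 2 (within the scatter), a number 4 percentage points lower from compound 1 to compound 3 (within the scatter) and a number 3 percentage points higher from compound 2 to compound 3 (within the scatter), each within the scatter: a carbamoyl, a 1H-tetrazol-5-yl and a 3-(methoxycarbonyl)phenyl at this place give indistinguishable inhibition.

Compound 4 `N#Cc1c(N)nc(SCc2nc3ccccc3[nH]2)c(C#N)c1-c1ccc(OCC2CC2)cc1` continues at the same place: 1H-benzimidazol-2-yl in place of 3-(methoxycarbonyl)phenyl on a saturated chain carbon bound to a sulfur. Because a number 4 percentage points lower from compound 1 to compound 3 (within the scatter) and a number 3 percentage points higher from compound 2 to compound 3 (within the scatter) both stayed within the scatter, the expected step is likewise none beyond the scatter, a number 1 percentage points higher from compound 3 to compound 4 (within the scatter). Going by the values given here, for compound 4 in this assay the estimate is therefore 5%, with a range from -6% to 18%, the range being widened because the benzimidazole has no measured precedent.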

Compound 4, a percentage reported as inhibition, at one concentration (the size of the read-out at that concentration, not a potency): 1%
The estimate for compound 4 lay 4 percentage points above the measured number; low and high end bracket the measured number.
By their numbers in this assay, from the lowest: compounds 2, 4, 3 and 1 (each within the scatter of the next).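

In this assay the 1H-benzimidazol-2-yl on a saturated chain carbon bound to a sulfur gives a number 3 percentage points lower from compound 3 to compound 4 (within the scatter) and no change at the digits printed from compound 2 to compound 4 (within the scatter) and a number 7 percentage points lower from compound 1 to compound 4 (within the scatter) and so separates from none of the three earlier groups. The new group differs from 3-(methoxycarbonyl)phenyl in carrying a five-membered aromatic ring with 2 hetero atoms alongside its six-membered aromatic ring of carbon only, and in having 1 hydrogen-bond donor and 1 hydrogen-bond acceptor, yet this change gives no readable difference in inhibition. The series now holds four different groups at this place with no order among them, and no measured evidence is at hand to account for this result.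

On these data alone, whether an amine, a carboxylic acid or a longer chain at this place would give a number beyond the scatter of these four remains open. Also open, as far as these compounds go, is whether any change elsewhere on the shared core would move the number, and what potency, if any, lies behind these readings at a single concentration.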